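Trisubstituted pyrazole chalcone analogue: next point to measure

This account rests on a few compounds, and the source may have more. Where it says the series, first, only, none or still open, it means among the compounds named here.

Of the compounds shown here, two from one series have been measured. Compound 1, `COc1ccc2c(c1)C/C(=C\c1cc(-c3cc(OC)c(OC)c(OC)c3)n[nH]1)C2=O`, gives 2100 nM in a functional assay on MCF7 cells (Homo sapiens) for inhibition, read by MTT assay, with a stated time of 48 h; a lower number here means a stronger inhibitor, a higher number a weaker inhibitor. Compound 2, `COc1cc(-c2cc(/C=C/C(=O)c3ccccc3)[nH]n2)cc(OC)c1OC`, gives 2100 nM in this assay. Compound 2 thus stands level with compound 1 at the digits shown; the two values lie within the scatter of each other, so no order between them can be claimed.

The piece follows the step from compound 2 to compound 3, `COc1ccc(C(=O)/C=C/c2cc(-c3cc(OC)c(OC)c(OC)c3)n[nH]2)cc1F`, which has not yet been measured in this assay. The change is 3-fluoro-4-methoxyphenyl in place of phenyl on a carbonyl carbon whose other neighbour is a double-bonded chain carbon. Among the compounds with values here, no step between two measured compounds of this kind is available, so the expectation rests only on the two values shown, which sit together. A step of modest size is expected, not clearly beyond the scatter, leaning if anything toward a stronger inhibitor. For compound 3 the estimated value in this assay is 1500 nM, with a range from 500 nM to 5000 nM, which means an expected step of a 1.4-fold lower number from compound 2 to compound 3 (0.15 log units; within the scatter).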

Compound 3, half-maximal inhibitory concentration: 3000 nM
For compound 3 the middle estimate is 2.0-fold (0.30 log units) below the measured one; the range from low to high includes it.
By their numbers in this assay, from the lowest: compounds 1, 2 and 3 (each within the scatter of the next).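

In this assay, 3-fluoro-4-methoxyphenyl in place of phenyl on a carbonyl carbon gives a 1.4-fold higher number from compound 2 to compound 3 (0.15 log units; within the scatter) so compound 2 and compound 3 cannot be put in order. This is the first view of this position among the compounds shown: the entering group has 9 heavy atoms where phenyl has 6 and brings 1 hydrogen-bond acceptor where phenyl has 0, yet the step does not leave the scatter, so this position accepts this larger substituted ring with no change that can be read in this assay. No measured property among the data bears on this result, so nothing can be said about what lies behind it.

As far as these compounds go, the fluorine and the methoxy group enter together in this one step, so what each does alone stays open, and one substituted ring on the carbonyl carbon gives no general rule for the position. Also open, from the compounds shown here alone, is whether a group of another kind in the same place, such as an aminophenyl or a carboxyphenyl group, would give a step beyond the scatter in either direction.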